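This account rests on a few compounds, and the source may have more. Where it says the series, first, only, none or still open, it means among the compounds named here.

In an in vitro functional assay on cells for agonist activity at Bombesin receptor subtype-3 (Homo sapiens), read by luminescence and calcium flux (a lower number here means that less compound is needed, a higher number that more compound is needed for the effect), compound 1 `COc1cccc(Cc2cnc(CCc3ccc(-c4ccccc4C(=O)O)cc3)[nH]2)c1` gives 4120 nM. Compound 2 `COc1ccccc1Cc1cnc(CCc2ccc(-c3ccccc3C(=O)O)cc2)[nH]1` differs from it in a single place, and in this assay compound 2 gives 1720 nM. Going by the values given here, that exchange, a 2.4-fold lower number from compound 1 to compound 2 (0.38 log units; beyond the scatter), moved the number beyond the scatter and leaves compound 2 with the lower of the two numbers measured so far. Compound 3 `O=C(O)c1ccccc1-c1ccc(CCc2ncc(CC3CCCCCC3)[nH]2)cc1` keeps the shared core of compound 2 but carries cycloheptyl in place of 2-methoxyphenyl on a saturated chain carbon bound to an aromatic carbon. Among the compounds with values here, the only measured step, a 2.4-fold lower number from compound 1 to compound 2 (0.38 log units; beyond the scatter), concerns the exchange of 3-methoxyphenyl for 2-methoxyphenyl; the change to compound 3 removes that aromatic ring altogether and puts a saturated ring in its place, so the measured step bears on it only loosely, showing merely that the group on this saturated chain carbon shifts the number in this assay by a modest amount. With no closer comparison at hand, the expected step is a 1.5-fold higher number from compound 2 to compound 3 (0.16 log units; within the scatter), small and without a firm direction. Compound 3 is therefore estimated to give about 2500 nM in this assay, with a likely range from 600 nM to 10000 nM.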

Compound 3, half-maximal effective concentration: 88 nM
For compound 3 the middle estimate is 28-fold (1.45 log units) above the measured one, and the stated range ends above it.
By their numbers in this assay, from the lowest: compound 3; then compound 2; then compound 1.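

In this assay, putting cycloheptyl in place of 2-methoxyphenyl on this saturated chain carbon gives a 20-fold lower number from compound 2 to compound 3 (1.29 log units; beyond the scatter), and putting it in place of 3-methoxyphenyl gives a 47-fold lower number from compound 1 to compound 3 (1.67 log units; beyond the scatter). Both steps are large, while moving the methoxy group around the aromatic ring gave only a 2.4-fold lower number from compound 1 to compound 2 (0.38 log units; beyond the scatter), so the kind of ring at this position matters far more here than where the methoxy group sits on it. An aromatic ring is also shown not to be needed at this position for a low number in this assay, although no measurement shown here explains why the saturated ring does so much better.

The exchange alters several things at once, since the ring goes from six to seven members, stops being aromatic and loses its methoxy group, and these three compounds cannot separate those changes. A cyclohexyl or cyclopentyl ring, a plain phenyl ring or an open hexyl chain at the same place would show which of them carries the drop.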